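Hydroxymethyl in place of the benzyl ester

The source may hold more compounds than are shown below. What is called first, only, known or untested is meant among the compounds shown, and "the series" means these compounds.

Measured in a functional assay on blood (Homo sapiens), with a stated time of 60 min, in the presence of a further agent that is not named here; a higher number here means that more compound is needed for the effect, a lower number that less compound is needed:
- compound 1 (`O=S(=O)(c1ccc(Oc2ccc(OC(F)(F)F)cc2)cc1)C1CCC2(CCNCC2)C1`): > 15000 nM (a limit)
- compound 2 (`O=C(O)C1(S(=O)(=O)c2ccc(Oc3ccc(OC(F)(F)F)cc3)cc2)CCC2(CCNCC2)C1`): 1800 nM
- compound 3 (`O=C(OCc1ccccc1)C1(S(=O)(=O)c2ccc(Oc3ccc(OC(F)(F)F)cc3)cc2)CCC2(CCNCC2)C1`): > 15000 nM (a limit)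

Compound 3 gives only a limit, > 15000 nM (no number). This is the limit of > 15000 nM in this assay, at which 2 of the 3 values shown sit.

Compound 4 (`O=S(=O)(c1ccc(Oc2ccc(OC(F)(F)F)cc2)cc1)C1(CO)CCC2(CCNCC2)C1`) carries hydroxymethyl in place of benzyloxycarbonyl on a saturated ring carbon.

For the measured compounds named here, two steps bear on this: carboxy in place of hydrogen gave an at least 8.3-fold lower number from compound 1 to compound 2 (0.92 log units; beyond the scatter) (the only route to a readable number), and adding benzyl to that carboxy gave an at least 8.3-fold higher number from compound 2 to compound 3 (0.92 log units; beyond the scatter) (a return to the limit). Neither step tests hydroxymethyl, so a modest step to a lower number in this assay is expected, and another limit remains possible.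

The expected change is an at least 2.1-fold lower number from compound 3 to compound 4 (0.33 log units; beyond the scatter) (an estimate). For compound 4 the estimated value is 7000 nM (expected range 2000 nM to 25000 nM).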

Compound 4, half-maximal effective concentration: > 15000 nM
Compound 4 gave a limit, no number (the forecaster's own chance of this, stated with the estimate: 45%); at least 2.1-fold (0.33 log units) between middle value and limit.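

In this assay compound 4 gives > 15000 nM, which is a limit and not a number. On this saturated ring carbon, hydroxymethyl in place of carboxy gives an at least 8.3-fold higher number from compound 2 to compound 4 (0.92 log units; beyond the scatter), so the readable result stays with carboxy alone among the groups shown here. The steps to compound 4 from compound 1 and from compound 3 cannot be read, and the values gather at one limit: the limit of > 15000 nM in this assay, at which 3 of the 4 values shown sit.

As far as these compounds go, whether a primary carboxamide or an acetic acid chain on this carbon would give a readable number stays open. From the compounds shown here alone, the order of compound 1, compound 3 and compound 4 also stays open, as none of them has a number.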